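Working Notes on Aryl Variation in the Series

The source may hold more compounds than are shown below. What is called first, only, known or untested is meant among the compounds shown, and "the series" means these compounds.

Compound 1 `COc1ccccc1NC(=S)N/N=C/c1ccc2ccccc2n1`: compound 1 gives 91700 nM in a functional assay on HL-60 cells (Homo sapiens) for antiproliferative activity, read by sulforhodamine B assay, with a stated time of 72 h; a lower number here means a stronger inhibitor, a higher number a weaker inhibitor
Compound 2 `Fc1ccccc1NC(=S)N/N=C/c1ccc2ccccc2n1`: compound 2 gives > 100000 nM in this assay, a limit of the assay rather than a number
Compound 3 `Cc1cccc(NC(=S)N/N=C/c2ccc3ccccc3n2)c1`: compound 3 gives > 100000 nM in this assay, again a limit rather than a number

Compound 3 thus stands at the limit of > 100000 nM in this assay, at which 2 of the 3 values shown sit. The steps that reach it read an at least 1.0-fold higher number from compound 1 to compound 3 (0.03 log units; that floor lies within the scatter) and a step that the two limits leave unreadable from compound 2 to compound 3, and the remaining measured step, an at least 1.0-fold higher number from compound 1 to compound 2 (0.03 log units; that floor lies within the scatter), is of the same kind: none of the three aryl groups gives a value that can be set apart from the others, and compound 1 alone yields a readable number.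

Compound 4 `N#Cc1ccc(NC(=S)N/N=C/c2ccc3ccccc3n2)cc1` has not been measured in this assay. It differs from compound 3 by 4-cyanophenyl in place of 3-methylphenyl on an amide-type nitrogen. Among the compounds with values here, no measured step introduces a nitrile, and no measured step starts from a readable number at the position changed here; the measured steps bear on the new step only in that every aryl change examined has left the value at or close to the limit. Compound 4 is expected to follow that pattern, with a number no higher from compound 3 to compound 4 (the limit leaves the size open) expected to be unreadable against the limit. The estimate for compound 4 is 100000 nM, between 30000 nM and 300000 nM.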

Compound 4, half-maximal inhibitory concentration: 4660 nM
Compound 4: the middle estimate sits 21-fold (1.33 log units) above what was measured; the measured number lies below the stated range.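

Within the data shown here, at this place, on the amide-type nitrogen whose other neighbour is the thiocarbonyl carbon, the aryl group can shift the value in this assay, which the earlier compounds did not show: the change to 4-cyanophenyl gives an at least 21-fold lower number from compound 3 to compound 4 (1.33 log units; beyond the scatter), an at least 21-fold lower number from compound 2 to compound 4 (1.33 log units; beyond the scatter) and a 20-fold lower number from compound 1 to compound 4 (1.29 log units; beyond the scatter). The flat picture therefore holds only among 2-methoxyphenyl, 2-fluorophenyl and 3-methylphenyl, and compound 4 goes against it. No measured property accounts for this step, and the record shows only how many of the values remain at the limit: the limit of > 100000 nM in this assay, at which 2 of the 4 values shown sit.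

Going by these compounds, whether the step belongs to the nitrile itself or to the whole exchange of 3-methylphenyl for 4-cyanophenyl stays open, since the two aryl groups differ in more than the nitrile. Also open, on these data alone, is how specific the effect is to the nitrile, which a carboxylic acid or an amine on the phenyl ring in its place would test, and how far a single readable gain of this kind extends across other aryl groups on the shared core.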